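Removing a Fluoro Group on an Aromatic Ring

This account rests on a few compounds, and the source may have more. Where it says the series, first, only, none or still open, it means among the compounds named here.

Compound 1 `Fc1ccc(Nc2cc(Nc3ccc(Oc4ccncc4-c4cccnc4)c(F)c3)ncn2)cc1F` and compound 2 `Fc1ccc(Nc2cc(Nc3ccc(Oc4ccncc4-c4cccnc4)c(F)c3)ncn2)cc1` share one core and differ at a single place, (hydrogen in place of fluoro on an aromatic carbon). In a functional assay on HT-29 cells (Homo sapiens) for cytotoxicity, read by MTT assay, with a stated time of 72 h (a lower number here means a stronger inhibitor, a higher number a weaker inhibitor), compound 1 gives 2320 nM, while compound 2 gives 330 nM, so that a 7.0-fold lower number from compound 1 to compound 2 (0.85 log units; beyond the scatter). Compound 3 `O=C(Nc1ccc(Oc2ccncc2-c2cccnc2)c(F)c1)c1nn(-c2cccc(F)c2)c(=O)c2ccccc12` rests on a different core; the difference between the two cores is not broken down here. In this assay compound 3 gives 410 nM, within the scatter of compound 2 and well apart from compound 1. Compound 4 `O=C(Nc1ccc(Oc2ccncc2-c2cccnc2)c(F)c1)c1nn(-c2ccccc2)c(=O)c2ccccc12` has not yet been measured in this assay. It differs from compound 3 by hydrogen in place of fluoro on an aromatic carbon. This is the same kind of change as that from compound 1 to compound 2, not the same one: in compound 1 the leaving fluoro sits ortho to a fluoro group and meta to a large group, whereas in compound 3 it sits only meta to a large group. Because a 7.0-fold lower number from compound 1 to compound 2 (0.85 log units; beyond the scatter), a lower number is expected for compound 4 as well, and with a different setting around the place a smaller step, a 2.1-fold lower number from compound 3 to compound 4 (0.31 log units; beyond the scatter), is expected. The estimate for compound 4 is 200 nM, between 80 nM and 500 nM.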

Compound 4, half-maximal inhibitory concentration: 1240 nM
Compound 4: the middle estimate sits 6.2-fold (0.79 log units) below what was measured, outside the stated range (above it).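

In this assay the change from 3-fluorophenyl to phenyl gave a 3.0-fold higher number from compound 3 to compound 4 (0.48 log units; beyond the scatter) and so ran the opposite way to the step seen on the other core. Set beside that earlier step, the two do not agree: the same change on two cores in this assay, a 7.0-fold lower number (0.85 log units; beyond the scatter) from compound 1 to compound 2 and a 3.0-fold higher number (0.48 log units; beyond the scatter) from compound 3 to compound 4, 21-fold (1.33 log units) apart, beyond the scatter of two such steps. This shows that the direction of the fluoro removal does not carry from the core of compound 1 to the core of compound 3, yet with a single pair on each core it does not show which difference between the cores, or in the surroundings of the fluoro group, is responsible, nor how the change would run on any further core.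

The compounds shown leave open whether the phenyl ring of compound 4 would respond in the same way to a chloro, methyl or methoxy group in place of the fluoro group, and so whether this step is particular to fluoro. They also leave open whether an amine or a carboxylic acid at that place would follow either of the two steps.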